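Replacing the triazolylamino group in compound 1 with a new ring

The compounds below may be only part of what the source reports. "The series", "measured", "known", "first", "only" and "open" are said of these compounds alone.

Measured compounds:
- compound 1, `CC(C)C(Nc1nnc[nH]1)c1ccc(-c2ccc3cccc(F)c3c2)[nH]c1=O`, 185 nM
- compound 2, `CCn1ncc2c(F)cc(-c3ccc(C(CC)(CC)c4nnc[nH]4)c(=O)[nH]3)cc21`, 29 nM
- compound 3, `CCn1ncc2c(F)cc(-c3ccc(C(CC)(CC)c4nncn4C)c(=O)[nH]3)cc21`, 120 nM

In a functional assay on CHO cells for antagonist activity at prostaglandin E2 receptor EP3 subtype (Homo sapiens), read by cAMP accumulation (on this read-out lower numbers stand for stronger inhibition and higher numbers for weaker inhibition), compound 1 gives the highest of the three numbers. Compound 3 lies a little lower, within the scatter, while compound 2 lies clearly lower, beyond the scatter.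

The unmeasured compound 4, `CC(C)C(Cc1noc(=O)[nH]1)c1ccc(-c2ccc3cccc(F)c3c2)[nH]c1=O`, is derived from compound 1 by one change: a group of 7 heavy atoms (3 carbon, 2 nitrogen, 2 oxygen; one five-membered aromatic ring with 3 hetero atoms) in place of a group of 6 heavy atoms (2 carbon, 4 nitrogen; one five-membered aromatic ring with 3 hetero atoms), on a saturated chain carbon bound to an aromatic carbon and a saturated chain carbon. Going by the values given here, the only measured step, a 4.1-fold higher number from compound 2 to compound 3 (0.62 log units; beyond the scatter), concerns a different kind of change, methyl in place of hydrogen on an aromatic nitrogen of the triazole, and is modest in size. It offers no direct guide to the exchange of the whole group together with its linking nitrogen, so the direction of the new step is not known from these data.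

The expectation for compound 4 is therefore a number close to that of compound 1, with a wide range, namely 200 nM between 60 nM and 700 nM, which means an estimated step of a 1.1-fold higher number from compound 1 to compound 4 (0.03 log units; within the scatter) in this assay .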

Compound 4, half-maximal inhibitory concentration: 70 nM
For compound 4 the middle estimate is 2.9-fold (0.46 log units) above the measured one, and the stated range covers the measured number.
By their numbers in this assay, from the lowest: compound 2; then compounds 4, 3 and 1 (each within the scatter of the next, the first and the last beyond it).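

In this assay the exchange of the (4H-1,2,4-triazol-3-yl)amino group for the new ring gives a 2.6-fold lower number from compound 1 to compound 4 (0.42 log units; beyond the scatter) and so shows that a change of the whole group at this saturated chain carbon can move the number downward, something the earlier methyl step on the triazole could not show. The linking nitrogen of compound 1 is thus not needed to keep activity at this read-out, and neither is the triazole ring itself, since a ring holding oxygen serves here even though the entering group has 1 hydrogen-bond donor where the leaving group has 2. Nothing available explains why the number falls.

Ring and link change together in this single step, so their separate shares stay unknown, and a triazole joined through a plain methylene group would be the compound to separate them. Also open, from the compounds shown here alone, is whether other groups at this carbon, such as a tetrazole ring or a carboxylic acid, would do as well, and whether the new ring would bring a similar change on the core of compound 2.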